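The source may report more compounds than this note shows. Statements on the series, on what has been measured and on what is new or still open speak of the compounds shown alone.

Compound 1 `CC(C)N(Cc1cccc(OCCCCCC(=O)O)c1)C(=O)c1ccc(-c2ccc3[nH]ccc3c2)cc1`: in an ADME assay on HepG2 cells (Homo sapiens) for cytotoxicity, read by CellTiter-Glo and resazurin assay, with a stated time of 72 h (a higher number here means that more compound is needed for the effect, a lower number that less compound is needed), compound 1 reaches only the limit > 26000 nM.
Compound 2 `CC(C)N(Cc1cccc(OCCCCCC(=O)O)c1)C(=O)c1ccc(-c2c[nH]c3ccccc23)cc1`: in this assay compound 2 reaches only the limit > 26000 nM.
Compound 3 `CC(C)N(Cc1cccc(OCCCCCC(=O)O)c1)C(=O)c1ccc(-c2cccc(Br)c2)cc1`: in this assay compound 3 reaches only the limit > 26000 nM.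

All three values are limits rather than numbers, and compound 3 stands exactly where the other two stand, at the limit of > 26000 nM in this assay, at which 3 of the 3 values shown sit. The steps a step that the two limits leave unreadable from compound 1 to compound 2, a step that the two limits leave unreadable from compound 1 to compound 3 and a step that the two limits leave unreadable from compound 2 to compound 3 are all unreadable: each joins two limits. Compound 4 `CC(C)N(Cc1cccc(OCCCCCC(=O)O)c1)C(=O)c1ccc(-c2cccc(Cl)c2)cc1` differs from compound 3 only by chloro in place of bromo on an aromatic carbon. Within the data shown here, no measured step speaks for or against this change, and every measured compound sits at the limit of > 26000 nM in this assay, at which 3 of the 3 values shown sit, so compound 4 is expected to remain at that limit as well, with a step that the limit leaves unreadable from compound 3 to compound 4 expected to be too small to read. Compound 4 is therefore estimated at 40000 nM, in the range 15000 nM to 100000 nM.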

Compound 4, half-maximal effective concentration: > 21900 nM
Compound 4: no number, only a limit; the forecaster's own chance of this, stated with the estimate: 85%; the middle value does not contradict the limit.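

Among these compounds, compound 1, compound 2, compound 3 and compound 4 all give only limits, and no step between them can be read. The compounds shown leave open the actual concentration at which any of them reaches half-maximal effect in this assay.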